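The source may report more compounds than this note shows. Statements on the series, on what has been measured and on what is new or still open speak of the compounds shown alone.

Compound 1 `O=S(=O)(/C=C/c1ccc(O)c(O)c1)NCc1ccc(F)cc1` gives 18900 nM in a functional assay on BV-2 cells (Mus musculus) for inhibition, read by Griess assay, with stated times of 3 h and 24 h; a lower number here means a stronger inhibitor, a higher number a weaker inhibitor. Compound 2 `Cc1ccc(CNS(=O)(=O)/C=C/c2ccc(O)c(O)c2)cc1` gives 43900 nM. Compound 3 `CC(=O)Oc1ccc(/C=C/S(=O)(=O)NCc2ccc(F)cc2)cc1OC(C)=O` gives 15500 nM.

Compound 1 and compound 2 share a core and differ only by methyl in place of fluoro on an aromatic carbon; this change brought a 2.3-fold higher number from compound 1 to compound 2 (0.37 log units; beyond the scatter). Compound 3 carries a different core; the difference between the two cores is not broken down here. Compound 4 `CC(=O)Oc1ccc(/C=C/S(=O)(=O)NCc2ccc(C)cc2)cc1OC(C)=O` is to compound 3 what compound 2 is to compound 1: it carries methyl in place of fluoro on an aromatic carbon, the same change at the same place. On the core of compound 3 the step is expected to be a 2.1-fold higher number from compound 3 to compound 4 (0.33 log units; beyond the scatter), because the same change gave a 2.3-fold higher number from compound 1 to compound 2 (0.37 log units; beyond the scatter) on the other core, while the difference between the cores shown by compound 1 and compound 3 lies within the scatter. Compound 4 is thus expected to give about 33000 nM in this assay, within 17000 nM to 65000 nM.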

Compound 4, half-maximal inhibitory concentration: 32000 nM
For compound 4 the middle estimate is 1.0-fold (0.01 log units) above the measured one; measured number inside the range.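

In this assay, methyl in place of fluoro on the aromatic carbon gave a 2.1-fold higher number from compound 3 to compound 4 (0.31 log units; beyond the scatter) and so carried over to the core of compound 3 at much the same size as on the core of compound 1: the same change on two cores in this assay, a 2.3-fold higher number (0.37 log units; beyond the scatter) from compound 1 to compound 2 and a 2.1-fold higher number (0.31 log units; beyond the scatter) from compound 3 to compound 4, 1.1-fold (0.05 log units) apart, within the scatter of two such steps. This agreement rests on two pairs of compounds in one assay, so it shows that the step held on these two cores and no further. It does not show why methyl gives the higher number, or whether the step would hold on any other core.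

The compounds shown leave open how chloro, methoxy or a carboxylic acid would behave at this place on either core. Also open, on these data alone, is whether a longer chain in place of the 4-fluorobenzyl or 4-methylbenzyl group would change the number.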